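This account rests on a few compounds, and the source may have more. Where it says the series, first, only, none or still open, it means among the compounds named here.

Working notes on the series. Compound 1 `O=C(/C=C/c1ccc2c(c1)B(O)OC2)c1cccs1`, compound 2 `O=C(/C=C/c1ccc2c(c1)B(O)OC2)c1cccnc1` and compound 3 `Cc1ccc(C(=O)/C=C/c2ccc3c(c2)B(O)OC3)cc1` share one core and differ only in the aryl group on the carbonyl carbon. In a functional assay on MDA-MB-231 cells (Homo sapiens) for cytotoxicity, read by MTT assay, with a stated time of 48 h (on this read-out higher numbers stand for weaker inhibition and lower numbers for stronger inhibition), compound 1 gives 4600 nM, compound 2 gives 11400 nM and compound 3 gives 6500 nM. For the measured compounds named here, compound 3 therefore sits within the scatter of both compound 1 and compound 2; the one step beyond the scatter in the set is a 2.5-fold higher number from compound 1 to compound 2 (0.39 log units; beyond the scatter). The two steps that end at compound 3, a 1.4-fold higher number from compound 1 to compound 3 (0.15 log units; within the scatter) and a 1.8-fold lower number from compound 2 to compound 3 (0.24 log units; within the scatter), stay within the scatter.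

Compound 4 `O=C(/C=C/c1ccc2c(c1)B(O)OC2)c1cccc(F)c1` is not yet measured. Its change from compound 3 is 3-fluorophenyl in place of 4-methylphenyl on a carbonyl carbon. Going by the values given here, the steps that bear on this are the two swaps of the aryl on the carbonyl carbon that reach compound 3, both within the scatter, while the step beyond the scatter involves pyridin-3-yl, which plays no part here. For compound 4 the expected step is no change at the digits printed from compound 3 to compound 4 (within the scatter), that is, none beyond the scatter. Compound 4 is estimated at 6500 nM in this assay, within a range of 3000 nM to 14000 nM.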

Compound 4, half-maximal inhibitory concentration: 3000 nM
Estimate against measurement, compound 4: 2.2-fold (0.34 log units) above, within the range that was stated.
By their numbers in this assay, from the lowest: compounds 4, 1, 3 and 2 (each within the scatter of the next, the first and the last beyond it).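

Among the aryl groups on the carbonyl carbon, this position now gives steps beyond the scatter that end at compound 4: 3-fluorophenyl in place of 4-methylphenyl gives a 2.2-fold lower number from compound 3 to compound 4 (0.34 log units; beyond the scatter) and 3-fluorophenyl in place of pyridin-3-yl gives a 3.8-fold lower number from compound 2 to compound 4 (0.58 log units; beyond the scatter) as the widest step in the set. Until now, the swaps reaching compound 3 had stayed within the scatter, and only pyridin-3-yl had stood apart from thiophen-2-yl. With 3-fluorophenyl in place of thiophen-2-yl, a 1.5-fold lower number from compound 1 to compound 4 (0.19 log units; within the scatter) sets those two groups level on this read-out.

No measurement here accounts for these steps.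

The compounds shown leave open whether the fluorine or the phenyl ring carries the step to compound 4. They also leave open how a phenyl ring bearing an amine or a carboxylic acid would read at this position.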